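A few compounds are considered here, and "the series" means these few. Any claim that something is new, unique, unknown or untested is made for them only; others in the source may bear on it.

Measured so far in an assay on membranes from brain with Neuronal acetylcholine receptor; alpha4/beta2 (Rattus norvegicus) as the target; on this read-out higher numbers stand for weaker inhibition and lower numbers for stronger inhibition:
- compound 1, `Clc1ncc(OC[C@@H]2CCN2)cc1-c1cccnc1`: 0.0081 nM
- compound 2, `Fc1ccc(-c2cc(OC[C@@H]3CCN3)cnc2Cl)cn1`: 0.0049 nM
- compound 3, `Clc1ncc(OC[C@@H]2CCN2)cc1-c1ccc(Br)nc1`: 0.0043 nM

All three share one core and differ only on the outer six-membered ring with one nitrogen. Compound 2 carries a fluoro group where compound 1 has hydrogen, (fluoro in place of hydrogen on an aromatic carbon); the step is a 1.7-fold lower number from compound 1 to compound 2 (0.22 log units; within the scatter). Compound 3 carries a bromo group at that same place, (bromo in place of hydrogen on an aromatic carbon), and the step is a 1.9-fold lower number from compound 1 to compound 3 (0.28 log units; within the scatter). Compound 2 and compound 3 sit within the scatter of each other, a 1.1-fold lower number from compound 2 to compound 3 (0.06 log units; within the scatter), so on this assay no order among the three is established.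

Compound 4, `Fc1ncc(-c2cc(OC[C@@H]3CCN3)cnc2Cl)cc1Br`, is not yet measured. It is derived from compound 2 by the same kind of change seen from compound 1 to compound 3: bromo in place of hydrogen on an aromatic carbon. The surroundings differ, though: in compound 3 the bromo group is next to the ring nitrogen and para to a large group, whereas in compound 4 it sits ortho to the fluoro group already present, two atoms from the ring nitrogen and meta to the large group, so the two bromo substitutions are the same kind of change and not the same change.

For compound 4 the expected step from compound 2 is a 1.4-fold lower number from compound 2 to compound 4 (0.15 log units; within the scatter), beside the earlier one, resting on compound 3 staying within the scatter of compound 1 after the bromo entry, a 1.9-fold lower number from compound 1 to compound 3 (0.28 log units; within the scatter), and on the value of compound 2 as starting point, 0.0049 nM. Compound 4 is accordingly estimated at 0.0035 nM, with a range from 0.0012 nM to 0.01 nM.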

Compound 4, inhibition constant: 0.004 nM
Compound 4: middle estimate off by 1.1-fold (0.06 log units), on the low side, and the stated range covers the measured number.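

In this assay, bromo in place of hydrogen on an aromatic carbon gives a 1.2-fold lower number from compound 2 to compound 4 (0.09 log units; within the scatter), so the new step stays within the scatter, as the earlier step on the core of compound 1 did. Set side by side, the two steps do not differ beyond what two such steps would show: the same change on two cores in this assay, a 1.9-fold lower number (0.28 log units; within the scatter) from compound 1 to compound 3 and a 1.2-fold lower number (0.09 log units; within the scatter) from compound 2 to compound 4, 1.5-fold (0.19 log units) apart, within the scatter of two such steps. Among these compounds, this shows that, on these two cores, the bromo entry leaves the number within the scatter of the compound that lacks it, even though the bromo group in compound 4 sits ortho to a fluoro group and the one in compound 3 sits elsewhere on the ring; it does not show that bromo strengthens inhibition on either core, and two pairs set no rule for other cores or other places on the ring.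

The compounds shown leave open whether any group on the outer ring moves the number beyond the scatter, as that ring carries only hydrogen, fluoro and bromo here. Going by these compounds, how a methoxy group, a nitrile or an amine would read at the same place remains open, as does what replacing the chloro group on the shared core would do.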